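A 1-methyl-1H-pyrrol-2-yl in place of 4-bromophenyl

A few compounds are considered here, and "the series" means these few. Any claim that something is new, unique, unknown or untested is made for them only; others in the source may bear on it.

Measured so far:
Compound 1 `CCN1CCN(CCC(=O)Nc2ccc3[nH]c(-c4ccc(Br)cc4)nc3c2)CC1`: 27400 nM
Compound 2 `Cc1ccc(-c2nc3cc(NC(=O)CN4CCCCC4)ccc3[nH]2)cc1`: > 50000 nM

Both compounds were tested in a functional assay on HepG2 cells (Homo sapiens) for cytotoxicity, read by MTT assay, with a stated time of 72 h; a lower number here means a stronger inhibitor, a higher number a weaker inhibitor. Compound 1 gives 27400 nM, a weak result. Compound 2 gives > 50000 nM, which is a limit of the assay rather than a number. Among the values shown, compound 1 is therefore the only one with an actual number; the other sits at a limit (the limit of > 50000 nM in this assay, at which 1 of the 2 values shown sits).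

Compound 3 `CCN1CCN(CCC(=O)Nc2ccc3[nH]c(-c4cccn4C)nc3c2)CC1` has not yet been measured. It differs from compound 1 in one place: 1-methyl-1H-pyrrol-2-yl in place of 4-bromophenyl on an aromatic carbon. The rest of the molecule stays the same. Within the data shown here, no measured pair differs in just one place, so no measured step shows how such a change plays out here.

The expected step is a 1.8-fold higher number from compound 1 to compound 3 (0.26 log units; within the scatter), toward weaker inhibition, though the size could well stay within the usual scatter. There is also a real chance that only a limit is reported, because compound 2 already sits at the limit of > 50000 nM in this assay, at which 1 of the 2 values shown sits. Compound 3 is expected to give about 50000 nM, with a range from 20000 nM to 150000 nM.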

Compound 3, half-maximal inhibitory concentration: > 50000 nM
Compound 3: a limit, no number (the forecaster's own chance of this, stated with the estimate: 50%); the middle value sits exactly at the limit.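

Replacing 4-bromophenyl with 1-methyl-1H-pyrrol-2-yl on this aromatic carbon, between two ring nitrogen atoms, gives in this assay an at least 1.8-fold higher number from compound 1 to compound 3 (0.26 log units; that floor lies within the scatter) and is the first step shown between two compounds that differ in one place. Compound 3 gives > 50000 nM in this comparison, which is a limit of the assay and not a number. The step therefore sets only a floor that stays within the usual scatter, so it shows neither a real loss from this swap nor how large any loss might be, and the true size stays hidden because the readings stop at a ceiling: the limit of > 50000 nM in this assay, at which 2 of the 3 values shown sit.

Still open, from the compounds shown here alone, is whether any group on this carbon can give a clearly lower number than compound 1, for example a phenyl ring carrying an amine or a carboxylic acid at the 4-position instead of bromine. Also open, going by these compounds, is how much the rest of the molecule matters, since a longer chain on the amide, with the shared core and the 4-bromophenyl kept unchanged, would test that part on its own.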